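Lengthening the chain: isopropyl to butyl on the core

The source may hold more compounds than are shown below. What is called first, only, known or untested is meant among the compounds shown, and "the series" means these compounds.

Measured so far in an assay for displacement of a labelled ligand from adenosine receptor A1 (Rattus norvegicus); on this read-out lower numbers stand for stronger inhibition and higher numbers for weaker inhibition:
compound 1 `CCC(Sc1nc(S)c2cnn(-c3ccccc3)c2n1)C(N)=O`: 155 nM
compound 2 `CCCCC(Sc1nc(N)c2cnn(-c3ccccc3)c2n1)C(N)=O`: 0.939 nM
compound 3 `CC(C)C(Sc1nc(S)c2cnn(-c3ccccc3)c2n1)C(N)=O`: 256 nM

Compound 3 stands at the highest of the three numbers, though compound 1 sits close by, and the step of a 1.7-fold higher number from compound 1 to compound 3 (0.22 log units; within the scatter) lies within the scatter. Compound 2 shows a far lower number, but it differs from compound 3 in two places, so its value alone cannot be tied to the chain.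

Compound 4 `CCCCC(Sc1nc(S)c2cnn(-c3ccccc3)c2n1)C(N)=O` differs from compound 3 by butyl in place of isopropyl on a saturated chain carbon bound to a carbonyl carbon and a sulfur. Among the compounds with values here, the only measured step at this chain carbon, from compound 1 to compound 3, was small, and no measured step isolates the change to butyl on this core. Compound 4 is therefore expected to show a modest step of a 2.8-fold lower number from compound 3 to compound 4 (0.45 log units; beyond the scatter) in this assay, estimated at 90 nM with a range from 15 nM to 500 nM.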

Compound 4, inhibition constant: 37.2 nM
Estimate against measurement, compound 4: 2.4-fold (0.38 log units) above; the measured number falls inside the stated range.
By their numbers in this assay, from the lowest: compound 2; then compound 4; then compounds 1 and 3 (each within the scatter of the next).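

In this assay, butyl on the saturated chain carbon bound to a carbonyl carbon and a sulfur gives a step beyond the scatter, seen in a 6.9-fold lower number from compound 3 to compound 4 (0.84 log units; beyond the scatter) and in a 4.2-fold lower number from compound 1 to compound 4 (0.62 log units; beyond the scatter), whereas the earlier step at this carbon lay within it. Butyl does not account for the whole reach of compound 2, however: sulfanyl in place of amino on an aromatic carbon gives the large step of a 40-fold higher number from compound 2 to compound 4 (1.60 log units; beyond the scatter) on the same chain. As far as these compounds go, what remains open is whether hexyl at this carbon would carry the trend further, and whether the butyl step holds with amino on the aromatic carbon. No evidence on the origin of these steps is at hand.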